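Swapping the anilide ring in a quinoline cytotoxicity series

A few compounds are considered here, and "the series" means these few. Any claim that something is new, unique, unknown or untested is made for them only; others in the source may bear on it.

Of the compounds shown here, three sharing a common core have been tested in a toxicity assay on HepG2 cells (Homo sapiens) for inhibition, read by CellTiter-Glo, with a stated time of 48 h; on this read-out higher numbers stand for weaker inhibition and lower numbers for stronger inhibition. Compound 1, `Cc1cc(C)cc(NC(=O)COc2cc(C)nc3ccc(OCc4ccccc4)cc23)c1`, carries a benzyloxy group on the core and an amide bearing a dimethylphenyl group; in this assay compound 1 reaches only the limit > 100000 nM, so no number is known for it, which is the limit of > 100000 nM in this assay, at which 1 of the 3 values shown sits. Compound 2, `COc1ccc2nc(C)cc(NCC(=O)Nc3cc(C)cc(C)c3)c2c1`, links the same dimethylphenyl amide through an amine nitrogen and gives 6310 nM. Going by the values given here, compound 3, `COc1ccc2nc(C)cc(OCC(=O)Nc3cccc(C)c3)c2c1`, links a 3-methylphenyl amide through an ether oxygen and gives 39800 nM, the higher of the two numbers known, with the gap to compound 2 beyond the usual scatter.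

Compound 4, `COc1ccc2nc(C)cc(OCC(=O)Nc3ccc(Cl)cc3)c2c1`, has not yet been measured. It differs from compound 3 in one place: 4-chlorophenyl in place of 3-methylphenyl on an amide-type nitrogen. Among the compounds with values here, no step between measured compounds isolates such a swap, so the expectation rests on the anilide ring being the only change. A step of a 1.3-fold lower number from compound 3 to compound 4 (0.12 log units; within the scatter) is expected, a slight move toward stronger inhibition but not clearly beyond the scatter. For compound 4 the estimated value in this assay is 30000 nM, expected to fall between 8000 nM and 100000 nM.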

Compound 4, half-maximal inhibitory concentration: > 100000 nM
Compound 4 gave a limit, no number; the forecaster's own chance of this, stated with the estimate: 20%; middle value at least 3.3-fold (0.52 log units) away from the limit.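

In this assay compound 4 gives > 100000 nM, which is a limit of the assay and not a number. Even so, placing 4-chlorophenyl instead of 3-methylphenyl on the amide-type nitrogen gives an at least 2.5-fold higher number from compound 3 to compound 4 (0.40 log units; beyond the scatter), the first step here that isolates a change in this ring, and it points toward weaker inhibition by more than the scatter, even though the two groups match in heavy-atom count and in hydrogen-bond donors and acceptors. The true size of this step stays unknown, for compound 4 reads only at the limit, the same place as one earlier compound: the limit of > 100000 nM in this assay, at which 2 of the 4 values shown sit.

This single swap changes both the substituent and its place on the ring, so the compounds shown cannot tell whether the chlorine, the loss of the methyl or the new position accounts for the step. An unsubstituted phenyl, a 3-chlorophenyl or a 4-methylphenyl on the same nitrogen would pull these apart, and an amine or a carboxylic acid on the ring would test whether this position accepts a very different kind of group.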